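A few compounds are considered here, and "the series" means these few. Any claim that something is new, unique, unknown or untested is made for them only; others in the source may bear on it.

Compound 1 `CCc1cn([C@H]2C[C@@H]3OP(=O)(O)OC[C@H]3O2)c(=O)[nH]c1=O` is the reference point of this pair. In a functional assay on L1210 cells (Mus musculus) (a lower number here means a stronger inhibitor, a higher number a weaker inhibitor), compound 1 gives > 500 ug/mL, which is a limit of the assay and not a number. A second measured compound, compound 2 `CCCc1cn([C@H]2C[C@H](O)[C@@H](CO)O2)c(=O)[nH]c1=O`, shares the same pyrimidine core with a different chain and a different sugar part. In this assay compound 2 gives > 500 ug/mL, again a limit rather than a number. Among the measured compounds shown here, both values shown therefore sit at the limit of > 500 ug/mL in this assay, at which 2 of the 2 values shown sit; compound 1 stands at that limit with no number of its own, and no step between measured compounds can be drawn.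

Compound 3 `CCCCCc1cn([C@H]2C[C@@H]3OP(=O)(O)OC[C@H]3O2)c(=O)[nH]c1=O` differs from compound 1 in one place: propyl in place of hydrogen on a saturated chain carbon, two bonds along the chain from an aromatic carbon. Since compound 1 rests at the limit of > 500 ug/mL in this assay, at which 2 of the 2 values shown sit, the step of a number no higher from compound 1 to compound 3 (the limit leaves the size open) is expected to be none beyond the scatter, with the reading most likely returned as a limit again. Compound 3 is estimated at about 500 ug/mL, within a range from 200 ug/mL to 1000 ug/mL.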

Compound 3, concentration for 50% inhibition: > 500 ug/mL
Compound 3 gave a limit, no number (the forecaster's own chance of this, stated with the estimate: 85%); the middle value lies on the limit itself.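

In this assay compound 3 gives > 500 ug/mL, a limit of the assay and not a number. With compound 1 also at a limit, no step from it to compound 3 can be read: the limit of > 500 ug/mL in this assay, at which 3 of the 3 values shown sit.

The compounds shown leave open whether any chain or sugar part in this series gives a measurable value in this assay.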